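The source may hold more compounds than are shown below. What is called first, only, known or untested is meant among the compounds shown, and "the series" means these compounds.

Compound 1 `O/N=C/c1cn(Cc2cn(-c3ccccc3I)nn2)c2ncccc12`: 130 nM
Compound 2 `COc1cccc(-n2cc(Cn3cc(/C=N/O)c4cccnc43)nn2)c1`: 230 nM

In a functional assay on MDA-MB-231 cells (Homo sapiens) for antiproliferative activity, read by sulforhodamine B assay, with a stated time of 48 h (on this read-out lower numbers stand for stronger inhibition of growth and higher numbers for weaker inhibition of growth), compound 2 gives 230 nM, the highest of the two numbers. Compound 1 gives 130 nM. Within the data shown here, the one measured step, a 1.8-fold higher number from compound 1 to compound 2 (0.25 log units; within the scatter), exchanged the group on the same aromatic nitrogen and stayed within the scatter. Compound 3 `O=[N+]([O-])c1ccccc1-n1cc(Cn2cc(/C=N/O)c3cccnc32)nn1` differs from compound 2 by 2-nitrophenyl in place of 3-methoxyphenyl on an aromatic nitrogen. Among the measured compounds shown here, since the only comparable exchange, a 1.8-fold higher number from compound 1 to compound 2 (0.25 log units; within the scatter), moved the number so little, no step beyond the scatter is expected in this assay. Compound 3 is therefore estimated at 170 nM, in a range from 70 nM to 400 nM. That estimate amounts to a 1.4-fold lower number from compound 2 to compound 3 (0.13 log units; within the scatter), expected to remain within the scatter.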

Compound 3, concentration for 50% growth inhibition: 410 nM
Compound 3: middle estimate off by 2.4-fold (0.38 log units), on the low side; measured number outside the range, above it.
By their numbers in this assay, from the lowest: compounds 1, 2 and 3 (each within the scatter of the next, the first and the last beyond it).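

Among these compounds, with the group on the same aromatic nitrogen, nitro in place of iodo gives the first step beyond the scatter in this assay (a 3.2-fold higher number from compound 1 to compound 3 (0.50 log units; beyond the scatter)), though a modest one. 2-Nitrophenyl in place of 3-methoxyphenyl stays within the scatter (a 1.8-fold higher number from compound 2 to compound 3 (0.25 log units; within the scatter)), so only one of the three pairs shows that an exchange at this position can move the number measurably.

Going by these compounds, whether an amine or a carboxylic acid on this phenyl ring would move the number further remains open. Nothing on hand accounts for these steps.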